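This account rests on a few compounds, and the source may have more. Where it says the series, first, only, none or still open, it means among the compounds named here.

Compound 1 `CC1CCC(Nc2nc(C(F)(F)F)ccc2CNC(=O)C(C)c2ccc(NS(C)(=O)=O)c(F)c2)CC1` is measured in a functional assay on CHO-K1 cells for antagonist activity at transient receptor potential cation channel subfamily V member 1 (Homo sapiens), read by FLIPR (a lower number here means a stronger inhibitor, a higher number a weaker inhibitor), at 1130 nM, the second highest of the three numbers shown. Compound 2 `Cc1ccc(Nc2nc(C(F)(F)F)ccc2CNC(=O)C(C)c2ccc(NS(C)(=O)=O)c(F)c2)cc1C` gives 1160 nM in this assay, and the step of a 1.0-fold higher number from compound 1 to compound 2 (0.01 log units; within the scatter) lies within the scatter. Compound 3 `CC(C(=O)NCc1ccc(C(F)(F)F)nc1N1CCC(Cc2cc(F)cc(F)c2)CC1)c1ccc(NS(C)(=O)=O)c(F)c1` gives 24 nM in this assay, a far lower number than compound 1. Compound 4 `CC(C(=O)NCc1ccc(C(F)(F)F)nc1N1CCC(C(F)(F)F)CC1)c1ccc(NS(C)(=O)=O)c(F)c1` arises from compound 1 by the change (4-(trifluoromethyl)piperidin-1-yl in place of (4-methylcyclohexyl)amino on an aromatic carbon). Among the compounds with values here, no measured step traces exactly this exchange; the step from compound 1 to compound 2 concerns only the group on the nitrogen and was flat, while compound 3 shows that a piperidin-1-yl at this place goes with a much lower number. Compound 4 is therefore expected to move as an 11-fold lower number from compound 1 to compound 4 (1.05 log units; beyond the scatter), toward an estimated 100 nM, somewhere between 25 nM and 400 nM.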

Compound 4, half-maximal inhibitory concentration: 31 nM
For compound 4 the middle estimate is 3.2-fold (0.51 log units) above the measured one; the measured number falls inside the stated range.
By their numbers in this assay, from the lowest: compounds 3 and 4 (each within the scatter of the next); then compounds 1 and 2 (each within the scatter of the next).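

In this assay, 4-(trifluoromethyl)piperidin-1-yl on this aromatic carbon next to the ring nitrogen gives a 36-fold lower number from compound 1 to compound 4 (1.56 log units; beyond the scatter) and also a 37-fold lower number from compound 2 to compound 4 (1.57 log units; beyond the scatter) in a comparison with the aromatic amino group. With the piperidine kept, trifluoromethyl in place of 3,5-difluorobenzyl gives a 1.3-fold higher number from compound 3 to compound 4 (0.11 log units; within the scatter) so the simpler substituent holds the number within the scatter. No evidence is available to explain the large steps.

The exchange removes the amino hydrogen and adds trifluoromethyl at once, so the compounds shown cannot separate the two changes. Unsubstituted piperidine, morpholine and (4-(trifluoromethyl)cyclohexyl)amino remain open.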